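The compounds below may be only part of what the source reports. "The series", "measured", "known", "first", "only" and "open" are said of these compounds alone.

In an ADME assay on Huh-7 cells (Homo sapiens) for cytotoxicity, with a stated time of 24 h (on this read-out lower numbers stand for higher toxicity in this test and higher numbers for lower toxicity in this test), three members of one series have been measured so far. Compound 1 `COc1ccc(/C=C\c2cc(OC)c(OC)c(OC)c2)cc1NC(=O)[C@H](C)NC(=O)[C@H](CCCNC(=N)N)NC(=O)[C@H](CCCCN)NC(=O)c1ccccc1` carries a benzoyl-capped tripeptide chain on the shared core; in this assay compound 1 gives > 100000 nM, which is a limit of the assay rather than a number (the limit of > 100000 nM in this assay, at which 1 of the 3 values shown sits). Compound 2 `COc1ccc(/C=C\c2cc(OC)c(OC)c(OC)c2)cc1NC(=O)CN` bears only the (aminomethyl)carbonyl group on the same core, and in this assay compound 2 gives 173000 nM. Compound 3 `COc1ccc(/C=C\c2cc(OC)c(OC)c(OC)c2)cc1NC(=O)CNC(=O)[C@H](CCCNC(=N)N)NC(=O)[C@H](CCCNC(=N)N)NC(=O)c1ccccc1`, with a longer benzoyl-capped chain, gives 88600 nM in this assay. Among the numbers shown, compound 2 and compound 3 lie within the usual scatter of each other, so no order between them can be read from these two values.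

The step now under consideration goes from compound 2 to compound 4 `COc1ccc(/C=C\c2cc(OC)c(OC)c(OC)c2)cc1NC(=O)[C@H](C)N`. The change is methyl in place of hydrogen on a saturated chain carbon bound to an amine nitrogen and a carbonyl carbon, that is, aminomethyl becoming 1-aminoethyl on the chain attached to the core. Within the data shown here, no measured pair in this set shows this change, so the expectation rests only on compound 2 and its neighbours, all of which sit at weak cytotoxicity in this assay. The step from compound 2 to compound 4 is expected to be a 1.0-fold lower number from compound 2 to compound 4 (0.01 log units; within the scatter), no larger than the scatter, in no firm direction. Compound 4 is therefore estimated at 170000 nM in this assay, with a range from 70000 nM to 400000 nM.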

Compound 4, half-maximal cytotoxic concentration: 123000 nM
Beside the measured number, compound 4's estimate is 1.4-fold (0.14 log units) above it; the measured number falls inside the stated range.
By their numbers in this assay, from the lowest: compounds 3, 4 and 2 (each within the scatter of the next).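

In this assay, among these compounds, methyl in place of hydrogen on a saturated chain carbon bound to an amine nitrogen and a carbonyl carbon gives a 1.4-fold lower number from compound 2 to compound 4 (0.15 log units; within the scatter), the first step between compounds that differ in one place. It shows that, with the amine left free, aminomethyl can become 1-aminoethyl without moving the number beyond the usual scatter, so no order can be read between these two compounds and this single step gives no sign that the methyl matters here. Nothing measured here bears on why the number responds in this way.

What the compounds shown leave open is whether a longer chain, such as ethyl, or a hydroxymethyl group on this carbon, or the opposite configuration there, would produce a step beyond the scatter. They also leave open how the same change behaves when the amine nitrogen carries a benzoyl-capped peptide chain, since compound 1 and compound 3 differ in more than one place.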